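This account rests on a few compounds, and the source may have more. Where it says the series, first, only, none or still open, it means among the compounds named here.

Compound 1 `CCCN(c1ccnc(Nc2ccc(C#N)cc2)n1)c1c(F)cc(-c2ccc(C#N)cc2)cc1F` gives 212000 nM in an ADME assay on MT4 cells (Homo sapiens) for cytotoxicity, read by MTT assay, with a stated time of 5 days; a higher number here means that more compound is tolerated, a lower number that less compound is tolerated. Compound 2 `CC(C)N(c1ccnc(Nc2ccc(C#N)cc2)n1)c1c(F)cc(-c2ccc(C#N)cc2)cc1F` gives 172000 nM in this assay. Compound 3 `N#Cc1ccc(Nc2nccc(N(c3c(F)cc(-c4ccc(C#N)cc4)cc3F)C3CCCC3)n2)cc1` gives 232000 nM in this assay.

Among these three, compound 2 has the smallest number, but its neighbours sit close: a 1.2-fold lower number from compound 1 to compound 2 (0.09 log units; within the scatter) and a 1.3-fold higher number from compound 2 to compound 3 (0.13 log units; within the scatter) both lie within the scatter, so no real separation between the three compounds can be claimed.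

Compound 4 `N#Cc1ccc(Nc2nccc(N(CC3CCCC3)c3c(F)cc(-c4ccc(C#N)cc4)cc3F)n2)cc1` has not yet been measured. Against compound 2 the change is cyclopentylmethyl in place of isopropyl on a nitrogen on an aromatic ring. All three measured steps bear on this change, since each of them swaps one alkyl group for another on the same nitrogen: a 1.2-fold lower number from compound 1 to compound 2 (0.09 log units; within the scatter), a 1.1-fold higher number from compound 1 to compound 3 (0.04 log units; within the scatter) and a 1.3-fold higher number from compound 2 to compound 3 (0.13 log units; within the scatter), every one within the scatter. The shared core, the nitrile-bearing rings and the two fluorine atoms are untouched in all of them.

On this basis the step to compound 4 in this assay is expected to be small as well, with no direction beyond the scatter, estimated as a 1.2-fold higher number from compound 2 to compound 4 (0.07 log units; within the scatter). The expected value for compound 4 is therefore 200000 nM, with a range from 110000 nM to 360000 nM.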

Compound 4, half-maximal cytotoxic concentration: > 247000 nM
Compound 4 gave a limit, no number; the forecaster's own chance of this, stated with the estimate: 15%; middle value at least 1.2-fold (0.09 log units) from the limit.
By their numbers in this assay, from the lowest: compounds 2, 1 and 3 (each within the scatter of the next). At a limit, above all of these: compound 4.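

Compound 4 gives a limit and no number in this assay: the limit of > 247000 nM in this assay, at which 1 of the 4 values shown sits.

Read against that limit, the steps are floors only: an at least 1.4-fold higher number from compound 2 to compound 4 (0.15 log units; that floor lies within the scatter), an at least 1.0-fold higher number from compound 3 to compound 4 (0.02 log units; that floor lies within the scatter) and an at least 1.1-fold higher number from compound 1 to compound 4 (0.06 log units; that floor lies within the scatter), so none of them by itself separates compound 4 from the other three compounds. What compound 4 adds is that the nitrogen on an aromatic ring can carry cyclopentylmethyl, with its 6 heavy atoms in place of the 3 of isopropyl, and the reading in this assay still does not fall below those of the earlier alkyl groups, which had covered only propyl, isopropyl and cyclopentyl.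

On these data alone, how far the true value of compound 4 lies beyond its limit remains unknown, and with it whether cyclopentylmethyl differs at all from the other groups at this position. All four groups shown are made of carbon only, so the compounds leave open what an amine, a carboxylic acid or a longer chain on this nitrogen would do to the number in this assay.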